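Swapping the pyridine attachment point in compound 1

A few compounds are considered here, and "the series" means these few. Any claim that something is new, unique, unknown or untested is made for them only; others in the source may bear on it.

Measured compounds:
compound 1, `Cc1cc(C)cc(Nc2nccc(-c3ccccn3)n2)c1`: 100 nM
compound 2, `CC1CCN(c2ccc(Nc3nccc(-c4cccnc4)n3)cc2)CC1`: 500 nM
compound 3, `Cc1cccc(Nc2nccc(-c3ccccn3)n2)c1`: 700 nM

All three numbers come from a functional assay for inhibition, with Homo sapiens as the target; a higher number here means a weaker inhibitor, a lower number a stronger inhibitor. Compound 1 gives the lowest number of the three and is the strongest inhibitor in this set; compound 2 lies beyond the scatter above it, and compound 3 lies further above still. For the measured compounds named here, the only single-place step measured is a 7.0-fold higher number from compound 1 to compound 3 (0.85 log units; beyond the scatter), a hydrogen in place of methyl on an aromatic carbon.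

Compound 4, `Cc1cc(C)cc(Nc2nccc(-c3cccnc3)n2)c1`, differs from compound 1 in one place: pyridin-3-yl in place of pyridin-2-yl on an aromatic carbon. Going by the values given here, no measured step isolates this exchange. Compound 2 does carry a pyridin-3-yl group and shows a higher number than compound 1, but it also differs in its other aromatic part, so its number cannot be pinned on the pyridine alone. A modest rise in the number is therefore the best guess, with wide uncertainty. Compound 4 is expected to give about 400 nM, within a range from 100 nM to 2000 nM. The estimated step of a 4.0-fold higher number from compound 1 to compound 4 (0.60 log units; beyond the scatter) rests on this reasoning, not on a measurement.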

Compound 4, half-maximal inhibitory concentration: 800 nM
For compound 4 the middle estimate is 2.0-fold (0.30 log units) below the measured one; the measured number falls inside the stated range.
By their numbers in this assay, from the lowest: compound 1; then compounds 2, 3 and 4 (each within the scatter of the next).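

In this assay, changing only the point at which the pyridine joins the core, with no atom gained or lost, gives an 8.0-fold higher number from compound 1 to compound 4 (0.90 log units; beyond the scatter) and a weaker inhibitor. For the compounds shown here, this is the first measured single-place change at this position, and it shows that pyridin-3-yl cannot stand in for pyridin-2-yl here without a loss of inhibition, even though the counts of heavy atoms, hydrogen-bond donors and hydrogen-bond acceptors stay the same. Nothing measured here explains this step.

Going by these compounds, it remains open whether pyridin-4-yl or a plain phenyl ring in this place would give a number nearer that of compound 1 or that of compound 4. On these data alone, it also remains open whether the same exchange would have a similar effect with a different group in place of the two methyl groups.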